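Swapping a methoxyethyl chain for a cyclohexyl ring

The source may hold more compounds than are shown below. What is called first, only, known or untested is meant among the compounds shown, and "the series" means these compounds.

Of the compounds shown here, three sharing one core have been tested in a functional assay on CHO cells for antagonist activity at adenosine receptor A2b (Homo sapiens); a higher number here means a weaker inhibitor, a lower number a stronger inhibitor. Compound 1 `CCOC(=O)c1cnc(NC2CC2)n2nc(-c3ccco3)nc12` carries a cyclopropyl group on the ring nitrogen and gives 2260 nM. Compound 2 `CCOC(=O)c1cnc(NCc2ccc(F)cc2)n2nc(-c3ccco3)nc12` carries a 4-fluorobenzyl group instead and gives 1970 nM; the step of a 1.1-fold lower number from compound 1 to compound 2 (0.06 log units; within the scatter) is within the scatter. Compound 3 `CCOC(=O)c1cnc(NCCOC)n2nc(-c3ccco3)nc12` carries a 2-methoxyethyl group and sits at the limit of this assay, > 10000 nM, so only a limit is known for it, not a number. Relative to the other two it is at least modestly weaker: an at least 4.4-fold higher number from compound 1 to compound 3 (0.64 log units; beyond the scatter) and an at least 5.0-fold higher number from compound 2 to compound 3 (0.70 log units; beyond the scatter).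

Compound 4 `CCOC(=O)c1cnc(NC2CCCCC2)n2nc(-c3ccco3)nc12` is not yet measured. Its difference from compound 3 is cyclohexyl in place of 2-methoxyethyl on a nitrogen on an aromatic ring. Among the compounds with values here, the measured step that bears on this change is the one from compound 1 to compound 3, where 2-methoxyethyl replaced cyclopropyl and the number rose at least modestly; reversing that direction, a carbon ring in place of the chain is expected to bring the number back down, toward the level of compound 1. Compound 4 is therefore estimated at 2000 nM, with a range from 600 nM to 7000 nM. That expectation amounts to a step of an at least 5.0-fold lower number from compound 3 to compound 4 (0.69 log units; beyond the scatter).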

Compound 4, inhibition constant: > 10000 nM
Compound 4 gave a limit, no number (the forecaster's own chance of this, stated with the estimate: 15%); middle value at least 5.0-fold (0.69 log units) away from the limit.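

In this assay a carbon ring on this nitrogen is not enough to keep a measurable value: compound 4, with its cyclohexyl group, gives > 10000 nM, which is a limit and not a number. Cyclohexyl in place of cyclopropyl brings an at least 4.4-fold higher number from compound 1 to compound 4 (0.64 log units; beyond the scatter), and cyclohexyl in place of 4-fluorobenzyl brings an at least 5.0-fold higher number from compound 2 to compound 4 (0.70 log units; beyond the scatter), so among these four compounds a carbon-only group can sit at the limit just as the oxygen-bearing 2-methoxyethyl chain does, and the oxygen of that chain is not needed for such a result. How compound 3 and compound 4 compare cannot be read, because both stand at the same limit: the limit of > 10000 nM in this assay, at which 2 of the 4 values shown sit.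

The compounds shown leave open how the value depends on ring size, and a cyclobutyl or cyclopentyl ring on the same nitrogen would show where between cyclopropyl and cyclohexyl the value is lost. They also leave open whether the fluorine of compound 2 matters, which a plain benzyl group would test, and whether an all-carbon chain such as n-butyl behaves like the 2-methoxyethyl chain.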